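Urea series: replacing the 3-(trifluoromethyl)phenyl group

The compounds below may be only part of what the source reports. "The series", "measured", "known", "first", "only" and "open" are said of these compounds alone.

Measured in a functional assay on NCI-H460 cells (Homo sapiens) for inhibition, read by MTT assay, with a stated time of 72 h; on this read-out lower numbers stand for stronger inhibition and higher numbers for weaker inhibition:
- compound 1 `COc1cc(NC(C)CCCNC(=O)NNC(=O)Nc2cccc(F)c2)c2ncccc2c1` gives 50000 nM 
- compound 2 `COc1cc(NC(C)CCCNC(=O)Nc2cccc(C(F)(F)F)c2)c2ncccc2c1` gives 21000 nM 

Of the two measured compounds, compound 2 has the lower number at 21000 nM and is the more potent of the pair. The next compound is compound 3 `COc1cc(NC(C)CCCNC(=O)Nc2ccc(O)cc2)c2ncccc2c1` with 4-hydroxyphenyl in place of 3-(trifluoromethyl)phenyl on an amide-type nitrogen. Going by the values given here, only one measured step bears on this change. It is a 2.4-fold lower number from compound 1 to compound 2 (0.38 log units; beyond the scatter) and it is modest, though beyond the scatter. Among the compounds with values here, that step acts at the same place but involves a different pair of groups, and no measured compound carries 4-hydroxyphenyl. Within the data shown here, it therefore suggests only that changes here may be modest and gives no firm direction. In this assay the expected result is no step beyond the scatter, with a wide margin on either side. The estimated step is a 1.2-fold higher number from compound 2 to compound 3 (0.08 log units; within the scatter) and remains uncertain. Compound 3 is estimated at 25000 nM with an expected range from 8000 nM to 70000 nM for this measurement.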

Compound 3, half-maximal inhibitory concentration: 34000 nM
Estimate against measurement, compound 3: 1.4-fold (0.13 log units) below; the measured number falls inside the stated range.
By their numbers in this assay, from the lowest: compounds 2, 3 and 1 (each within the scatter of the next, the first and the last beyond it).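

In this assay, going by these compounds alone, the exchange of 3-(trifluoromethyl)phenyl for 4-hydroxyphenyl on the amide-type nitrogen gives a 1.6-fold higher number from compound 2 to compound 3 (0.21 log units; within the scatter) and is the first change at this place with a step that stays within the scatter. Replacing ((3-fluorophenyl)carbamoyl)amino with 4-hydroxyphenyl at the same place gives a 1.5-fold lower number from compound 1 to compound 3 (0.17 log units; within the scatter) and cannot be told apart from the scatter either, so compound 3 cannot be ranked against compound 1 or compound 2, although the step of a 2.4-fold lower number from compound 1 to compound 2 (0.38 log units; beyond the scatter) separates those two. Fluorine-bearing groups are therefore not the only ones compatible with numbers in this range, since a group with one hydrogen-bond donor and one hydrogen-bond acceptor gives compound 3 at 34000 nM in this assay, and no measurement here accounts for this result.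

Still open, on these data alone, is whether an amine or a carboxylic acid in place of the hydroxyl on the phenyl ring would produce a step beyond the scatter from compound 3. Also open, as far as these compounds go, is whether a longer chain in place of the one in the shared core would move the numbers further than any change on the amide-type nitrogen has so far.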